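The source may hold more compounds than are shown below. What is called first, only, known or untested is meant among the compounds shown, and "the series" means these compounds.

Measured compounds:
compound 1 `COc1cc(OC)c(OC)cc1/C=C/COC(=O)/C=C/c1ccc(Br)cc1`: in a functional assay on the whole organism (strain Kunming) with Mus musculus as the target, with a stated time of 0.5 h, at a dose of 300 mg/kg by the intraperitoneal route (a lower number here means a stronger effect, a higher number a weaker effect of the compound at the dose given), compound 1 gives 100%
compound 2 `COc1cc(OC)c(OC)cc1/C=C/COC(=O)/C=C/c1cccc(Br)c1`: in this assay compound 2 gives 100%
compound 3 `COc1cc(OC)c(OC)cc1/C=C/COC(=O)/C=C/c1ccccc1Cl`: in this assay compound 3 gives 100%

On these numbers compound 3 stands level with compounds 1 and 2: the step of no change at the digits printed from compound 1 to compound 3 (within the scatter) and the step of no change at the digits printed from compound 2 to compound 3 (within the scatter) both lie within the scatter, as does no change at the digits printed from compound 1 to compound 2 (within the scatter). All three compounds share the same core and differ only in the halogenated phenyl group on the chain.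

Compound 4 `COc1cccc(/C=C/C(=O)OC/C=C/c2cc(OC)c(OC)cc2OC)c1` is not yet measured. The change from compound 3 is 3-methoxyphenyl in place of 2-chlorophenyl on a double-bonded chain carbon bound to a double-bonded chain carbon. The three measured steps are the only ones that bear on it; each exchanges one substituted phenyl for another at this same place, and none moved the read-out beyond the scatter. The entering group is of a different kind from anything the measured steps test, so the support is indirect. Still, on the steps shown, no change beyond the scatter is expected: no change at the digits printed from compound 3 to compound 4 (within the scatter). Compound 4 is estimated at 100%, with a range from 80% to 100%.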

Compound 4, a percentage reported as activity, at one dose (the size of the read-out at that dose, not a potency): 100%
Compound 4: middle estimate and measured number agree at the digits printed; the range from low to high includes it.
By their numbers in this assay, from the lowest: compounds 1, 2, 3 and 4 (each within the scatter of the next).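

With 3-methoxyphenyl, this place on a double-bonded chain carbon bound to a double-bonded chain carbon now holds a group with no halogen and with a hydrogen-bond acceptor, and this assay shows no change at the digits printed from compound 3 to compound 4 (within the scatter) for that exchange. The read-out is equally flat against the two bromo compounds, with no change at the digits printed from compound 2 to compound 4 (within the scatter) for methoxy in place of bromo on an aromatic carbon and no change at the digits printed from compound 1 to compound 4 (within the scatter) for the exchange of 4-bromophenyl, so the insensitivity at this place is no longer confined to halogenated phenyl groups. Nothing available on these compounds accounts for this flat result.

Going by these compounds, with all four compounds level, it stays open whether any group at this place can lower the read-out at all. A phenyl carrying an amine or a carboxylic acid, or a longer chain at this place, would test that.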